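The compounds below may be only part of what the source reports. "The series", "measured", "known", "first", "only" and "open" are said of these compounds alone.

Measured in a functional assay on HeLa cells (Homo sapiens) for cytotoxicity, read by MTT assay, with a stated time of 24 h; a higher number here means a weaker inhibitor, a lower number a stronger inhibitor:
Compound 1 `C=CC1=C(C(=O)NCc2ccccc2)C(c2ccc(OC)c(OC)c2)OC1` gives > 100000 nM, which is a limit of the assay and not a number.
Compound 2 `C=CC1=C(C(=O)NCc2ccccc2)C(c2ccc(OC)cc2)OC1` gives > 100000 nM, again a limit.
Compound 3 `C=CC1=C(C(=O)O)C(c2ccc(OC)cc2)OC1` gives 44300 nM.

Compound 2 stands at the top of the series only as a limit; two of the three values sit at that same point (the limit of > 100000 nM in this assay, at which 2 of the 3 values shown sit), so the step that the two limits leave unreadable from compound 1 to compound 2 cannot be read. For the measured compounds named here, the one readable step is an at least 2.2-fold lower number from compound 2 to compound 3 (0.35 log units; beyond the scatter), which exchanges the amide for an acid and moves the number in this assay by a modest amount.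

Compound 4 `C=CC1=C(C(=O)Nc2ccc(OCC)cc2)C(c2ccc(OC)cc2)OC1` differs from compound 2 by 4-ethoxyphenyl in place of benzyl on an amide-type nitrogen. Going by the values given here, no measured step changes the amide substituent in this way; the step from compound 2 to compound 3 removes the benzylamino group altogether, which is a different change, and the methoxy step between compound 1 and compound 2 is unreadable. With compound 2 known only as a limit, a step of the size seen between compound 2 and compound 3 would still leave compound 4 near that limit. The expected step of a number no higher from compound 2 to compound 4 (the limit leaves the size open) is therefore none beyond the scatter. Compound 4 is estimated at 100000 nM, within 30000 nM to 300000 nM, most likely reported as a limit.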

Compound 4, half-maximal inhibitory concentration: > 100000 nM
Compound 4 ended at the assay's limit (the forecaster's own chance of this, stated with the estimate: 65%); the middle value sits exactly at the limit.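

Compound 2 and compound 4 end at the same limit, so the change from benzyl to 4-ethoxyphenyl on the amide-type nitrogen gives no readable step: the limit of > 100000 nM in this assay, at which 3 of the 4 values shown sit.

Left open is how these two amide substituents compare on a readable number, and whether any amide on the shared core gives a value short of that limit.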